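Statin-type lactones: aryl exchange on the biaryl of compound 1

This account rests on a few compounds, and the source may have more. Where it says the series, first, only, none or still open, it means among the compounds named here.

Measured compounds in this series:
- compound 1, `O=C1C[C@H](O)C[C@@H](/C=C/c2c(Cl)cc(Cl)cc2-c2cc(Cl)cc(Cl)c2)O1`: 37 nM
- compound 2, `O=C1C[C@H](O)CC(CCc2c(Cl)cc(Cl)cc2-c2ccccc2)O1`: 100 nM
- compound 3, `Cc1ccc(C)c(-c2ccc(Cl)c(Cl)c2)c1/C=C/[C@@H]1C[C@@H](O)CC(=O)O1`: 13 nM

All three numbers come from an assay for inhibition of 3-hydroxy-3-methylglutaryl-coenzyme A reductase (Rattus norvegicus); a higher number here means a weaker inhibitor, a lower number a stronger inhibitor. Compound 1 stands second highest of the three: compound 2 gives 100 nM, a higher number than compound 1 and beyond the scatter, while compound 3 gives 13 nM, a lower number than compound 1 and likewise beyond the scatter. Among the compounds with values here, no pair among the three differs in only one place, so none of these gaps can be read as a single structural step.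

The next compound, compound 4, `COc1cccc(-c2cc(Cl)cc(Cl)c2/C=C/[C@@H]2C[C@@H](O)CC(=O)O2)c1`, is derived from compound 1 by a single change:
3-methoxyphenyl in place of 3,5-dichlorophenyl on an aromatic carbon
The lactone, the vinyl linker and the two chloro groups on the inner ring are kept; only the outer aryl is exchanged.

Within this series the outer aryl has not been varied on its own, so there is no measured step to lean on. Compound 2, with an unsubstituted phenyl at that place but also a saturated linker, gives 100 nM, which hints that losing the two chloro groups from the outer ring may cost some potency, though the linker change in compound 2 confounds that reading. A slight weakening in this assay is expected, a 1.9-fold higher number from compound 1 to compound 4 (0.28 log units; within the scatter). Compound 4 is therefore estimated at 70 nM, with a range of 25 nM to 200 nM.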

Compound 4, half-maximal inhibitory concentration: 50 nM
Compound 4: middle estimate off by 1.4-fold (0.15 log units), on the high side; the range from low to high includes it.
By their numbers in this assay, from the lowest: compound 3; then compounds 1, 4 and 2 (each within the scatter of the next, the first and the last beyond it).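

In this assay, within the data shown here, exchanging 3,5-dichlorophenyl for 3-methoxyphenyl gives a 1.4-fold higher number from compound 1 to compound 4 (0.13 log units; within the scatter) with the rest of the structure held fixed, the first reading of the outer aryl on its own. This aromatic carbon, ortho to a large group, therefore accepts an outer ring with no chloro groups and one methoxy group, without a difference that can be separated from the scatter. Nothing at hand bears on why the two outer aryl groups read alike.

This single exchange removes both chloro groups and adds the methoxy group together, so the contribution of each remains unresolved. Also open, on these data alone, is how the same position responds to an outer ring carrying an amine or a carboxylic acid, or to a non-aromatic group such as cyclohexyl in place of the aryl.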